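Amide substituent change on an inactive dihydrofuran carboxamide series

The compounds below may be only part of what the source reports. "The series", "measured", "known", "first", "only" and "open" are said of these compounds alone.

Measured so far:
compound 1 `C=CC1=C(C(=O)NC(C)(C)C)C(c2ccc(OC)cc2)OC1`, > 100000 nM
compound 2 `C=CC1=C(C(=O)Nc2ccccc2OC)C(c2ccc(OC)cc2)OC1`, > 100000 nM
compound 3 `C=CC1=C(C(=O)Nc2ccccc2OC)C(c2ccc(Cl)c(Cl)c2)OC1`, > 100000 nM

Compound 2 is the reference here. In a functional assay on SW480 cells (Homo sapiens) for cytotoxicity, read by MTT assay, with a stated time of 24 h (on this read-out higher numbers stand for weaker inhibition and lower numbers for stronger inhibition), compound 2 gives only a limit, > 100000 nM, not a number. Compound 1 likewise gives only a limit in this assay, > 100000 nM. Compound 3 too gives only a limit in this assay, > 100000 nM. Because all three values sit at the limit of > 100000 nM in this assay, at which 3 of the 3 values shown sit, neither a step that the two limits leave unreadable from compound 1 to compound 2 nor a step that the two limits leave unreadable from compound 2 to compound 3 can be read for size or direction; the change on the amide-type nitrogen and the change on the saturated ring carbon both leave the series at the limit.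

Compound 4 `C=CC1=C(C(=O)NCC(C)C)C(c2ccc(OC)cc2)OC1` differs from compound 2 as follows: isobutyl in place of 2-methoxyphenyl on an amide-type nitrogen. The nearest comparison is compound 1, which also bears a branched alkyl group on the amide-type nitrogen and gives only a limit. Among the compounds with values here, no measured step gives a readable size, so no step beyond the scatter is expected in this assay; compound 4 is expected to remain at the limit as well, estimated at 150000 nM with a range from 50000 nM to 500000 nM. The estimated step that the limit leaves unreadable from compound 2 to compound 4 is thus expected to be unreadable in practice.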

Compound 4, half-maximal inhibitory concentration: > 100000 nM
Compound 4 was reported as a limit; the forecaster's own chance of this, stated with the estimate: 85%; the middle value lies beyond the limit too.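

In this assay, within the data shown here, compound 4 gives > 100000 nM as a limit only, so no step from compound 1 or compound 2 to compound 4 can be read. The compounds shown leave open whether any change on the amide-type nitrogen or the saturated ring carbon gives a measurable value: the limit of > 100000 nM in this assay, at which 4 of the 4 values shown sit.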